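This account rests on a few compounds, and the source may have more. Where it says the series, first, only, none or still open, it means among the compounds named here.

Measured so far in an assay on cells for displacement of a labelled ligand from metabotropic glutamate receptor 2 (Homo sapiens), read by scintillation counting, with a stated time of 60 min; a lower number here means a stronger inhibitor, a higher number a weaker inhibitor:
compound 1, `Cc1cc(Oc2ccc(-c3ccn4c(CC5CC5)nnc4c3Cl)cc2F)ccn1`, compound 1 gives 63.1 nM
compound 2, `Cc1cc(Oc2ccc(-c3ccn4c(CC5CC5)nnc4c3C(F)(F)F)cc2F)ccn1`, compound 2 gives 7.08 nM
compound 3, `CC(C)Nc1ccc(-c2ccn3c(CC4CC4)nnc3c2Cl)cc1F`, compound 3 gives 61.7 nM

One change has been measured once: trifluoromethyl in place of chloro on an aromatic carbon, giving an 8.9-fold lower number from compound 1 to compound 2 (0.95 log units; beyond the scatter) in this assay. The two cores differ by isopropylamino in place of (2-methylpyridin-4-yl)oxy on an aromatic carbon, and in this assay this gives a 1.0-fold lower number from compound 1 to compound 3 (0.01 log units; within the scatter), so the two cores sit together.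

Compound 4, `CC(C)Nc1ccc(-c2ccn3c(CC4CC4)nnc3c2C(F)(F)F)cc1F`, is not yet measured. It differs from compound 3 by trifluoromethyl in place of chloro on an aromatic carbon, the same change as from compound 1 to compound 2, described in the same words at the same kind of place. In this assay the step from compound 3 to compound 4 is expected to be a 7.7-fold lower number from compound 3 to compound 4 (0.89 log units; beyond the scatter), resting on the measured 8.9-fold lower number from compound 1 to compound 2 (0.95 log units; beyond the scatter) and on the cores of compound 1 and compound 3 giving numbers within scatter of one another, a 1.0-fold lower number from compound 1 to compound 3 (0.01 log units; within the scatter). Compound 4 is therefore estimated at 8 nM, expected to lie between 3 nM and 22 nM.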

Compound 4, inhibition constant: 8.91 nM
For compound 4 the middle estimate is 1.1-fold (0.05 log units) below the measured one; low and high end bracket the measured number.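

In this assay the change of chloro to trifluoromethyl carries over from one core to the other, with a 6.9-fold lower number from compound 3 to compound 4 (0.84 log units; beyond the scatter) matching the earlier step: the same change on two cores in this assay, an 8.9-fold lower number (0.95 log units; beyond the scatter) from compound 1 to compound 2 and a 6.9-fold lower number (0.84 log units; beyond the scatter) from compound 3 to compound 4, 1.3-fold (0.11 log units) apart, within the scatter of two such steps.
The exchange of (2-methylpyridin-4-yl)oxy for isopropylamino likewise stays within the scatter on the trifluoromethyl side, with a 1.3-fold higher number from compound 2 to compound 4 (0.10 log units; within the scatter) matching its counterpart on the chloro side: the same change on two cores in this assay, a 1.0-fold lower number (0.01 log units; within the scatter) from compound 1 to compound 3 and a 1.3-fold higher number (0.10 log units; within the scatter) from compound 2 to compound 4, 1.3-fold (0.11 log units) apart, within the scatter of two such steps.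
This shows that the two changes add up across these four compounds, but it rests on two cores only and gives neither a rule for the wider series nor a reason for the size of the step.

Open, going by these compounds, is whether a nitrile or a methyl at the same place would behave like trifluoromethyl. Also open, on these data alone, is whether the step would hold on a core carrying morpholine or a longer alkylamine chain in place of isopropylamino.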